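The compounds below may be only part of what the source reports. "The series", "measured", "known", "first", "only" and "open" are said of these compounds alone.

Measured compounds in the series:

compound 1, `O=C1NC(=O)/C(=C\c2ccc(OCC(=O)N3N=C(c4ccc(F)cc4)CC3c3ccco3)cc2)S1` — 880 nM
compound 2, `O=C1NC(=O)/C(=C\c2ccc(OCC(=O)N3N=C(c4ccc(F)cc4)CC3c3ccc(C(F)(F)F)cc3)cc2)S1` — 1300 nM
compound 3, `O=C1NC(=O)/C(=C\c2ccc(OCC(=O)N3N=C(c4ccc(F)cc4)CC3c3ccc(F)cc3F)cc2)S1` — 1600 nM

All three share one core and differ only in the aryl group on a saturated ring carbon of the five-membered ring with two nitrogens. In an assay on cells for inhibition of histone deacetylase 4 (Homo sapiens), read by fluorescence, with a stated time of 30 min (a higher number here means a weaker inhibitor, a lower number a stronger inhibitor), compound 3 gives the highest of the three numbers, but every step separating it from the others falls within the scatter: a 1.8-fold higher number from compound 1 to compound 3 (0.26 log units; within the scatter) and a 1.2-fold higher number from compound 2 to compound 3 (0.09 log units; within the scatter). For the measured compounds named here, the one further step among the measured compounds, a 1.5-fold higher number from compound 1 to compound 2 (0.17 log units; within the scatter), is likewise within the scatter. On these numbers compound 3 cannot be called weaker than compound 1 or compound 2; the three are indistinguishable.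

Compound 4, `Cc1ccc(C2CC(c3ccc(F)cc3)=NN2C(=O)COc2ccc(/C=C3/SC(=O)NC3=O)cc2)cc1`, continues the same exchange at the same position: 4-methylphenyl in place of 2,4-difluorophenyl on a saturated ring carbon. The three measured steps that bear on this position all change the aryl group there, and none of them moved this assay beyond the scatter. The expectation for compound 4 is therefore a step of no clear size in either direction, a 1.2-fold lower number from compound 3 to compound 4 (0.09 log units; within the scatter), and the number is estimated to sit near the measured compounds. Compound 4 is thus expected at 1300 nM, with a range of 600 nM to 3000 nM.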

Compound 4, half-maximal inhibitory concentration: 1800 nM
Beside the measured number, compound 4's estimate is 1.4-fold (0.14 log units) below it; the range from low to high includes it.
By their numbers in this assay, from the lowest: compounds 1, 2, 3 and 4 (each within the scatter of the next, the first and the last beyond it).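

In this assay, 4-methylphenyl and 2,4-difluorophenyl on this saturated ring carbon cannot be told apart (a 1.1-fold higher number from compound 3 to compound 4 (0.05 log units; within the scatter)), and methyl in place of trifluoromethyl on the aromatic carbon leaves the reading equally unresolved (a 1.4-fold higher number from compound 2 to compound 4 (0.14 log units; within the scatter)), so compound 2, compound 3 and compound 4 form one group within the scatter. For the compounds shown here, the only step at this position to pass the scatter is the exchange of furan-2-yl for 4-methylphenyl (a 2.0-fold higher number from compound 1 to compound 4 (0.31 log units; beyond the scatter)), and it is modest, while the exchanges of furan-2-yl for the aryl groups of compound 2 and compound 3 stay within the scatter. Nothing available on these compounds accounts for that single step.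

Every group shown at this position is an aromatic ring, so the response to a cyclohexyl ring, a longer alkyl chain, or a phenyl ring carrying an amine or a carboxylic acid remains open. As far as these compounds go, the 4-fluorophenyl group and the rest of the shared core are constant throughout, so the effect of a change at those places in this assay is also open.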